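Morpholine in Place of Thiomorpholine: Compound 4 Expected

This account rests on a few compounds, and the source may have more. Where it says the series, first, only, none or still open, it means among the compounds named here.

Compound 1 `Cc1ccnc(/C(N)=N/NC(=S)N2CCSCC2)c1` gives 6900 nM in a functional assay on MCF7 cells (Homo sapiens) for cytotoxicity, read by MTT assay, with a stated time of 72 h; on this read-out lower numbers stand for stronger inhibition and higher numbers for weaker inhibition. Compound 2 `Cc1ccnc(/C(N)=N/NC(=S)N2CCCCCC2)c1` gives 6900 nM in this assay, level with compound 1 at the digits shown, and the two stand together as the highest of the three numbers. Within the data shown here, compound 3 `N/C(=N\NC(=S)N1CCCCCC1)c1ccccn1` gives 2600 nM; the only step measured within one change, a 2.7-fold lower number from compound 2 to compound 3 (0.42 log units; beyond the scatter), is modest and concerns the aromatic methyl, not the ring on the thiocarbonyl carbon. Compound 4 `Cc1ccnc(/C(N)=N/NC(=S)N2CCOCC2)c1` carries morpholin-4-yl in place of thiomorpholin-4-yl on a thiocarbonyl carbon. Among the measured compounds shown here, no measured step bears on this exchange; compound 1 and compound 2, which differ in that ring, show values level with each other. Compound 4 is therefore expected to give 6900 nM, within 3000 nM to 16000 nM. The expected step is no change at the digits printed from compound 1 to compound 4 (within the scatter), nothing beyond the scatter.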

Compound 4, half-maximal inhibitory concentration: > 100000 nM
Compound 4 was reported as a limit; the forecaster's own chance of this, stated with the estimate: 10%; middle value at least 14-fold (1.16 log units) from the limit.
By their numbers in this assay, from the lowest: compound 3; then compounds 1 and 2 (each within the scatter of the next). At a limit, above all of these: compound 4.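

Compound 1 and compound 2 stood level, so the ring on the thiocarbonyl carbon had seemed to allow wide change, but in this assay morpholin-4-yl in place of thiomorpholin-4-yl gives an at least 14-fold higher number from compound 1 to compound 4 (1.16 log units; beyond the scatter). The two groups match in every count except that oxygen replaces sulfur, so this single atom decides the outcome here. Compound 4 is reported only as a limit: the limit of > 100000 nM in this assay, at which 1 of the 4 values shown sits.

The compounds shown leave open whether the same exchange has this effect without the aromatic methyl. They also leave open how a piperazin-1-yl or piperidin-1-yl ring would fare at this place.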